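Swapping a piperidine tail for a methylpiperazine on a pyrazole core

A few compounds are considered here, and "the series" means these few. Any claim that something is new, unique, unknown or untested is made for them only; others in the source may bear on it.

Compound 1 `Cc1ccccc1-c1nn(-c2ccc(F)cc2F)cc1CNCCN1CCCCC1`: > 20000 nM
Compound 2 `CN1CCN(CCCNCc2cn(-c3ccc(C(F)(F)F)cc3)nc2-c2ccc(Cl)cc2)CC1`: 2500 nM

In an ADME assay on Huh-7 cells (Homo sapiens) for cytotoxicity (on this read-out lower numbers stand for higher toxicity in this test and higher numbers for lower toxicity in this test), compound 1 reaches only a limit, > 20000 nM, so its true place in this test is not pinned down by a number. Compound 2, a different member of the same series, gives 2500 nM in this assay. These two values cannot be compared directly, since for compound 1 only the limit is known (the limit of > 20000 nM in this assay, at which 1 of the 2 values shown sits).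

Compound 3 `Cc1ccccc1-c1nn(-c2ccc(F)cc2F)cc1CNCCCN1CCN(C)CC1` is the next compound to be tested. It differs from compound 1 in one place: (4-methylpiperazin-1-yl)methyl in place of piperidin-1-yl on a saturated chain carbon, two bonds along the chain from an amine nitrogen. Among the compounds with values here, no measured pair in this set shares exactly this change, so the size of the step rests on the two values shown. Since compound 1 sits at the limit, any move toward greater toxicity would appear as a finite number, while a move in the other direction would stay hidden at the limit. Compound 3 is expected to come out somewhat more toxic than the limit for compound 1, a step of an at least 2.0-fold lower number from compound 1 to compound 3 (0.30 log units; that floor lies within the scatter), with an estimated value of 10000 nM in this assay, in a range from 3000 nM to 30000 nM.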

Compound 3, half-maximal cytotoxic concentration: > 20000 nM
Compound 3: a limit, no number (the forecaster's own chance of this, stated with the estimate: 40%); at least 2.0-fold (0.30 log units) between middle value and limit.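

In this assay compound 3 gives > 20000 nM as a limit, not a number. Compound 1 likewise gives > 20000 nM as a limit. Within the data shown here, no step from compound 1 to compound 3 can be read, with both values at a limit: the limit of > 20000 nM in this assay, at which 2 of the 3 values shown sit.

The compounds shown leave open whether (4-methylpiperazin-1-yl)methyl in place of piperidin-1-yl shifts the read-out in this assay at all.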